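A pyrimidine-to-pyridine switch and the next substituent change

A few compounds are considered here, and "the series" means these few. Any claim that something is new, unique, unknown or untested is made for them only; others in the source may bear on it.

Of the compounds shown here, two of the shared core have been measured. Compound 1 `CC(C)(C)c1ccc(S(=O)(=O)Nc2ccc(Cl)cc2-c2c(O)ccc[n+]2[O-])cc1` gives 1750 nM in an assay on isolated protein for antagonist activity at C-C chemokine receptor type 9 (Homo sapiens); a higher number here means a weaker inhibitor, a lower number a stronger inhibitor. Compound 2 `CN(C)c1ncnc(-c2cc(Cl)ccc2NS(=O)(=O)c2ccc(C(C)(C)C)cc2)c1O` gives 105 nM in this assay, the lowest of the two numbers, and the step of a 17-fold lower number from compound 1 to compound 2 (1.22 log units; beyond the scatter) is large. Compound 3 `CC(C)(C)c1ccc(S(=O)(=O)Nc2ccc(Cl)cc2-c2ncnc(CO)c2O)cc1` is not yet measured; it differs from compound 2 by hydroxymethyl in place of dimethylamino on an aromatic carbon. Among the measured compounds shown here, no measured step concerns this exchange: the only step in hand, from compound 1 to compound 2, swaps the whole ring and says nothing about what a hydroxymethyl in place of a dimethylamino does. For compound 3 the expectation therefore rests on the value of compound 2 alone, and the estimated step of a 1.5-fold higher number from compound 2 to compound 3 (0.18 log units; within the scatter) is taken as none beyond the scatter, with wide room either way. Compound 3 is accordingly expected to give about 160 nM in this assay, within the range 40 nM to 700 nM.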

Compound 3, half-maximal inhibitory concentration: 325 nM
Beside the measured number, compound 3's estimate is 2.0-fold (0.31 log units) below it, within the range that was stated.
By their numbers in this assay, from the lowest: compound 2; then compound 3; then compound 1.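

In this assay this position, next to the ring nitrogen and ortho to a hydroxy group, proved sensitive to its substituent: hydroxymethyl in place of dimethylamino gave a 3.1-fold higher number from compound 2 to compound 3 (0.49 log units; beyond the scatter) and so the two groups are not interchangeable here. The lower number relative to compound 1 did not depend on dimethylamino alone, since the hydroxymethyl-bearing group still gave a 5.4-fold lower number from compound 1 to compound 3 (0.73 log units; beyond the scatter) in the same assay. Nothing at hand explains why the number rose with this exchange.

The compounds shown leave open whether the rise follows from the dimethylamino group leaving or the hydroxymethyl group entering. As far as these compounds go, how an amine such as methylamino, an ether such as methoxymethyl or a longer chain such as hydroxyethyl would read on this aromatic carbon also remains open.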